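Chain shortening in a cytotoxicity series of tricarboxylic acid amides

The compounds below may be only part of what the source reports. "The series", "measured", "known", "first", "only" and "open" are said of these compounds alone.

Compound 2 `CCCCCCCCCCCCCCCCCCCC(=O)NC(CCC(=O)O)(CCC(=O)O)CCC(=O)O` and compound 1 `CCCCCCCCCCCCCC(=O)NC(CCC(=O)O)(CCC(=O)O)CCC(=O)O` differ only by hydrogen in place of hexyl on a saturated chain carbon, ten or more bonds along the chain from a carbonyl carbon. In an ADME assay on cells (Epithelial cell, Homo sapiens) for cytotoxicity, read by MTT assay (on this read-out higher numbers stand for an effect only at larger amounts of compound and lower numbers for an effect already at smaller amounts), compound 2 gives 340000 nM, and compound 1 gives 300000 nM; the step of a 1.1-fold lower number from compound 2 to compound 1 (0.05 log units; within the scatter) lies within the scatter. Compound 3 `CCCCCCCCCCCCCCCCCCCCOC(=O)NC(CCC(=O)O)(CCC(=O)O)CCC(=O)O` gives 280000 nM in this assay, and its values against compound 1 and compound 2 are within the scatter of each other. The difference between the core of compound 3 and the core of compound 2 is not broken down here.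

Compound 4 `CCCCCCCCCCCCCCOC(=O)NC(CCC(=O)O)(CCC(=O)O)CCC(=O)O` is not yet measured. It differs from compound 3 by hydrogen in place of hexyl on a saturated chain carbon, ten or more bonds along the chain from an oxygen next to a carbonyl group. This is the same kind of change as that from compound 2 to compound 1, though its place along the chain is described differently in the two cases. Because the step of a 1.1-fold lower number from compound 2 to compound 1 (0.05 log units; within the scatter) was within the scatter, the step of a 1.0-fold higher number from compound 3 to compound 4 (0.02 log units; within the scatter) is expected to be small as well. Compound 4 is therefore estimated at 290000 nM in this assay, with a likely range from 150000 nM to 550000 nM.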

Compound 4, half-maximal effective concentration: 620000 nM
Estimate against measurement, compound 4: 2.1-fold (0.33 log units) below; measured number above the stated range.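

In this assay, hydrogen in place of hexyl on a saturated chain carbon, ten or more bonds along the chain from an oxygen next to a carbonyl group, gives a 2.2-fold higher number from compound 3 to compound 4 (0.35 log units; beyond the scatter), a modest step, while the same change on the core of compound 2 gives a 1.1-fold lower number from compound 2 to compound 1 (0.05 log units; within the scatter). Set side by side, the two steps cannot be told apart: the same change on two cores in this assay, a 1.1-fold lower number (0.05 log units; within the scatter) from compound 2 to compound 1 and a 2.2-fold higher number (0.35 log units; beyond the scatter) from compound 3 to compound 4, 2.5-fold (0.40 log units) apart, within the scatter of two such steps. This shows no firm dependence of the change on the core, but with a single pair on each core it also does not show that the change carries over unchanged from one core to the other.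

Still open is how the read-out runs on both cores with a chain shorter than those shown, such as octyl, and whether the two steps then draw apart or stay together. Also open, going by these compounds, is what happens when an amine takes the place of one carboxylic acid on the shared core.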